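A Dichlorophenyl Swap in an Inactive Spirocyclic Series

The source may report more compounds than this note shows. Statements on the series, on what has been measured and on what is new or still open speak of the compounds shown alone.

Three compounds have so far been tested in a functional assay on HepG2 cells (Homo sapiens) for antiproliferative activity, read by MTT assay, with a stated time of 48 h (on this read-out lower numbers stand for stronger inhibition and higher numbers for weaker inhibition), and every result is a limit of the assay rather than a number:

Compound 1 `COc1ccccc1-n1nncc1CN1C(=O)C2(C(C#N)=C(N)Oc3c2c2nc4ccccc4nc2c2ccccc32)c2ccccc21`: > 50000 nM
Compound 2 `N#CC1=C(N)Oc2c(c3nc4ccccc4nc3c3ccccc23)C12C(=O)N(Cc1cnnn1-c1ccc([N+](=O)[O-])cc1)c1ccccc12`: > 50000 nM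
Compound 3 `CC(=O)Nc1ccc(-n2nncc2CN2C(=O)C3(C(C#N)=C(N)Oc4c(N)cc5nc6ccccc6nc5c43)c3ccccc32)cc1`: > 50000 nM

Compound 3 thus stands only at a limit in this assay. Among the measured compounds shown here, the two other values shown are limits of the same kind, so no compound can be ranked against another. For the measured compounds named here, the one step between measured compounds that differ in a single place, a step that the two limits leave unreadable from compound 1 to compound 2, cannot be read because both of its ends sit at the limit of > 50000 nM in this assay, at which 3 of the 3 values shown sit.

Compound 4 `N#CC1=C(N)Oc2c(N)cc3nc4ccccc4nc3c2C12C(=O)N(Cc1cnnn1-c1ccc(Cl)cc1Cl)c1ccccc12` has not yet been measured. It differs from compound 3 in one place: 2,4-dichlorophenyl in place of 4-acetamidophenyl on an aromatic nitrogen. Going by the values given here, no measured step touches this change, and the only step available is itself unreadable, so the expectation for compound 4 rests on the fact that every value shown sits at the limit of > 50000 nM in this assay, at which 3 of the 3 values shown sit. The step of a number no higher from compound 3 to compound 4 (the limit leaves the size open) is therefore expected to be none beyond the scatter, leaving the result at the limit. Compound 4 is estimated at 50000 nM, within a range from 20000 nM to 100000 nM, and most likely to be reported once more as a limit.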

Compound 4, half-maximal inhibitory concentration: > 50000 nM
Compound 4 was reported as a limit; the forecaster's own chance of this, stated with the estimate: 85%; the middle value sits exactly at the limit.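

No new step can be read from compound 3 to compound 4, since in this assay both results are limits and not numbers, so the size of the swap of 2,4-dichlorophenyl in place of 4-acetamidophenyl stays unknown because every result shown is the same limit: the limit of > 50000 nM in this assay, at which 4 of the 4 values shown sit.

The compounds shown leave open which change to the shared core, if any, would give a measurable number.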